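Adding a second selenium-bearing group to compound 3

A few compounds are considered here, and "the series" means these few. Any claim that something is new, unique, unknown or untested is made for them only; others in the source may bear on it.

Values from an ADME assay on cells (Peritoneal macrophage, Mus musculus, strain Swiss) for cytotoxicity, with a stated time of 24 h (on this read-out higher numbers stand for lower toxicity in this test and lower numbers for higher toxicity in this test), follow
- compound 1 `O=C1C(Cl)=C(Cl)C(=O)c2c(I)cccc21` gives 27800 nM
- compound 2 `O=C1C=CC(=O)C(I)=C1` gives 86000 nM
- compound 3 `O=C1C=CC(=O)C([Se]c2ccccc2)=C1` gives 13800 nM

Compound 3 lies within the scatter of compound 1, while compound 2 stands beyond the scatter at a higher number. The change to compound 4 `O=C1C=C([Se]c2ccccc2)C(=O)C=C1[Se]c1ccccc1` is a group of 7 heavy atoms (6 carbon, 1 selenium; one six-membered aromatic ring of carbon only) in place of a hydrogen atom, on a double-bonded ring carbon, three ring bonds from the ring atom that already bears such a group. Going by the values given here, no measured pair shows this change, so the expectation rests only on compound 3 at 13800 nM and is weak. A move within the scatter, if anything towards a lower number, is expected, and the estimated step is a 1.3-fold lower number from compound 3 to compound 4 (0.10 log units; within the scatter) in size. Compound 4 is estimated at 11000 nM, within an expected range of 3500 nM to 35000 nM for this read-out.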

Compound 4, concentration lethal to 50% of the cells: > 100000 nM
Compound 4: a limit, no number (the forecaster's own chance of this, stated with the estimate: 10%); at least 9.0-fold (0.95 log units) between middle value and limit.
By their numbers in this assay, from the lowest: compounds 3 and 1 (each within the scatter of the next); then compound 2. At a limit, above all of these: compound 4.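

In this assay compound 4 gives > 100000 nM, which is a limit of the assay and not a number. Placing a second group of 7 heavy atoms (6 carbon, 1 selenium) on the double-bonded ring carbon gives an at least 7.2-fold higher number from compound 3 to compound 4 (0.86 log units; beyond the scatter). This position therefore responds to the change, and the shift runs towards lower toxicity in this test.

Going by these compounds, whether an amine or a carboxylic acid on the same ring carbon would shift the read-out in the same way stays open. How far the step reaches also stays open: the limit of > 100000 nM in this assay, at which 1 of the 4 values shown sits.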